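The source may report more compounds than this note shows. Statements on the series, on what has been measured and on what is new or still open speak of the compounds shown alone.

Compound 1 `O=C(Nc1cccc(-n2cc(-c3ccncc3)c(-c3cc(O)cc(Cl)c3)n2)c1)Nc1ccc(Cl)c(C(F)(F)F)c1` and compound 3 `O=C(Nc1cccc(-n2cc(-c3ccncc3)c(-c3cc(O)cc(Cl)c3)n2)c1)c1cc(C(F)(F)F)cc(C(F)(F)F)c1` have much in common, but the difference between the two cores is not broken down here. In a functional assay on MCF7 cells (Homo sapiens) for inhibition, read by sulforhodamine B assay, with a stated time of 48 h, tested at 10 uM (on this read-out lower numbers stand for a stronger effect and higher numbers for a weaker effect at the one concentration tested), compound 1 gives 13.4% and compound 3 gives 23%, two numbers that lie within the usual scatter of one another. Compound 2 `COc1cc(Cl)cc(-c2nn(-c3cccc(NC(=O)Nc4ccc(Cl)c(C(F)(F)F)c4)c3)cc2-c2ccncc2)c1` differs from compound 1 by methyl in place of hydrogen on an oxygen on an aromatic ring. In this assay compound 2 gives 2.57%, which is a step of a number 10.8 percentage points lower from compound 1 to compound 2 (beyond the scatter). Compound 4 `COc1cc(Cl)cc(-c2nn(-c3cccc(NC(=O)c4cc(C(F)(F)F)cc(C(F)(F)F)c4)c3)cc2-c2ccncc2)c1` is not yet measured; it differs from compound 3 by methyl in place of hydrogen on an oxygen on an aromatic ring, the same change at the same place as that between compound 1 and compound 2. Within the data shown here, a step of about the same size is expected this time, because the earlier step of a number 10.8 percentage points lower from compound 1 to compound 2 (beyond the scatter) is the only measured instance of this change and compound 3 starts from a number close to that of compound 1. The expected step is therefore a number 11 percentage points lower from compound 3 to compound 4 (beyond the scatter). Compound 4 is estimated at 12%, with a likely range from 2% to 24%.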

Compound 4, a percentage reported as activity, at one concentration (the size of the read-out at that concentration, not a potency): 57.8%
The estimate for compound 4 lay 45.8 percentage points below the measured number; measured number outside the range, above it.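

In this assay, the change from hydroxy to methoxy now gives a number 34.8 percentage points higher from compound 3 to compound 4 (beyond the scatter), which points towards a weaker effect, the opposite direction to the earlier step. The two steps do not agree: the same change on two cores in this assay, a number 10.8 percentage points lower (beyond the scatter) from compound 1 to compound 2 and a number 34.8 percentage points higher (beyond the scatter) from compound 3 to compound 4, 45.6 percentage points apart, beyond the scatter of two such steps. This shows that the result of this change on one core did not predict its result on the other, so in this series it cannot simply be carried across, but two pairs do not show why the direction reverses or how the change would behave on any further core.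

The compounds shown leave open which part of the difference between the two cores goes with the reversal. From the compounds shown here alone, it is also open how each core would respond to other groups at this place, such as an ethoxy group, with its longer chain on the oxygen, or an amine in place of the hydroxy.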